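Methoxy Addition in a Weakly Cytotoxic Isoquinolinone Pair

A few compounds are considered here, and "the series" means these few. Any claim that something is new, unique, unknown or untested is made for them only; others in the source may bear on it.

The measured compounds:
compound 1, `COCOCc1cc(OC)ccc1-c1cc2ccccc2c(=O)[nH]1`, 45300 nM
compound 2, `C=CCn1c(-c2ccc(OC)cc2C=O)cc2ccccc2c1=O`, 88100 nM
compound 3, `COCOCc1cc(OC)c(OC)cc1-c1cc2ccccc2c(=O)[nH]1`, 85100 nM

In a functional assay on A549 cells (Homo sapiens) for cytotoxicity, read by MTT assay, with a stated time of 48 h (a lower number here means a stronger inhibitor, a higher number a weaker inhibitor), compound 1 gives 45300 nM, and compound 3 gives 85100 nM. The two share a core and differ only in one spot: methoxy in place of hydrogen on an aromatic carbon. That change gave a 1.9-fold higher number from compound 1 to compound 3 (0.27 log units; within the scatter). Compound 2 belongs to the same set; its value in this assay is 88100 nM. How compound 2 differs from compound 1 is not broken down here, since the two differ in more than one place.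

Compound 4, `C=CCn1c(-c2cc(OC)c(OC)cc2C=O)cc2ccccc2c1=O`, has not yet been measured. It is made from compound 2 by the same kind of change: methoxy in place of hydrogen on an aromatic carbon. The surroundings are not identical, though: in compound 3 the new methoxy sits para to a (methoxymethoxy)methyl group, whereas in compound 4 it sits para to a formyl group.

Compound 4 is expected to show a 1.6-fold higher number from compound 2 to compound 4 (0.20 log units; within the scatter), a step which rests on a 1.9-fold higher number from compound 1 to compound 3 (0.27 log units; within the scatter), a change that stayed within the scatter. Compound 4 is therefore estimated at 140000 nM, with a plausible range from 60000 nM to 350000 nM.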

Compound 4, half-maximal inhibitory concentration: 76300 nM
The estimate for compound 4 lay 1.8-fold (0.26 log units) above the measured number; measured number inside the range.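

In this assay, adding methoxy in place of hydrogen on an aromatic carbon gave a 1.2-fold lower number from compound 2 to compound 4 (0.06 log units; within the scatter). Set beside the earlier step, the result on the second core does not differ measurably from the result on the first: the same change on two cores in this assay, a 1.9-fold higher number (0.27 log units; within the scatter) from compound 1 to compound 3 and a 1.2-fold lower number (0.06 log units; within the scatter) from compound 2 to compound 4, 2.2-fold (0.34 log units) apart, within the scatter of two such steps. This shows that, within the resolution of this assay, the change behaved alike on the two cores, but with both steps inside the scatter it does not show that methoxy has any real effect on either core, or that the two steps are truly equal.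

The compounds shown leave open whether a different group on that aromatic carbon, such as an amine or a carboxylic acid, would produce a step large enough to be read beyond the scatter. They also leave open whether a change with a clear effect would carry from one core to the other, since neither step here is large enough to test that.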